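Working notes: chloro to trifluoromethyl, compound 2 to compound 4

The source may report more compounds than this note shows. Statements on the series, on what has been measured and on what is new or still open speak of the compounds shown alone.

Measured so far:
- compound 1, `Cc1ccc(OCC(=O)N(Cc2cccs2)c2c[nH]nc2C)cc1`, 0.4 nM
- compound 2, `CCN(Cc1cccs1)C(=O)COc1ccc(Cl)cc1`, 39 nM
- compound 3, `CCN(Cc1cccs1)C(=O)COc1cc(C)ccc1O`, 24 nM

All three were run in an assay on HEK293 cells for agonist activity at transient receptor potential cation channel subfamily M member 8 (Homo sapiens), read by fluorescence and calcium flux, with a stated time of 15 min; on this read-out lower numbers stand for an effect already at smaller amounts and higher numbers for an effect only at larger amounts of compound. Compound 2 gives the highest number of the three. Its nearest neighbour on the numbers is compound 3, whose value lies within the scatter of that of compound 2, so no order between the two can be stated. Compound 1 stands far apart, with a number well beyond the scatter below that of compound 2; compound 1 differs from compound 2 in more than one place, so no single change can be credited.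

The next compound, compound 4, `CCN(Cc1cccs1)C(=O)COc1ccc(C(F)(F)F)cc1`, differs from compound 2 in one place: trifluoromethyl in place of chloro on an aromatic carbon. Among the measured compounds shown here, no measured pair shows this change, so there is no step to lean on.

The expectation is a step from compound 2 to compound 4 of a 1.0-fold higher number from compound 2 to compound 4 (0.01 log units; within the scatter) in this assay, that is no change beyond the scatter. Compound 4 is therefore estimated at 40 nM, with a range from 12 nM to 130 nM.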

Compound 4, half-maximal effective concentration: 236 nM
The estimate for compound 4 lay 5.9-fold (0.77 log units) below the measured number, and the stated range ends below it.
By their numbers in this assay, from the lowest: compound 1; then compounds 3 and 2 (each within the scatter of the next); then compound 4.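

Working notes: in this assay, trifluoromethyl in place of chloro on an aromatic carbon, para to a large group, gives a 6.1-fold higher number from compound 2 to compound 4 (0.78 log units; beyond the scatter) and is the only single-place step so far in this series. The position therefore does not treat these two groups alike, although neither carries a hydrogen-bond donor, a hydrogen-bond acceptor or a net charge and the heavy-atom count rises only from 1 to 4. No measurement is at hand that bears on the cause of this step.

Still open, on these data alone, is whether other groups at this position, such as methoxy, nitrile or an amine, stay near chloro or move with trifluoromethyl. Also open, as far as these compounds go, is whether the same exchange gives a step of like size on the core of compound 1.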